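From an Oxane Chain to a Fluoropiperidine Urea

The source may report more compounds than this note shows. Statements on the series, on what has been measured and on what is new or still open speak of the compounds shown alone.

Of the compounds shown here, three sharing one core have been tested in an assay on HEK293 cells for positive allosteric modulation of metabotropic glutamate receptor 5 (Homo sapiens), read by FLIPR, with a stated time of 1 h; a lower number here means that less compound is needed, a higher number that more compound is needed for the effect. Compound 1 `CCC(=O)N1CCc2nc(C#Cc3ccccc3)sc2C1` carries a propanoyl group on the ring nitrogen. In this assay compound 1 gives > 10000 nM, which is a limit of the assay rather than a number. Compound 2 `O=C(C1CC1)N1CCc2nc(C#Cc3ccccc3)sc2C1` carries a cyclopropanecarbonyl group, and in this assay compound 2 also gives > 10000 nM, again a limit rather than a number. For the measured compounds named here, compound 3 `O=C(CC1CCOCC1)N1CCc2nc(C#Cc3ccccc3)sc2C1` gives 470 nM, the only actual number among the three; the other two values sit at the limit of > 10000 nM in this assay, at which 2 of the 3 values shown sit. Between compounds 1 and 2 the step that the two limits leave unreadable from compound 1 to compound 2 cannot be sized. The steps of an at least 21-fold lower number from compound 1 to compound 3 (1.32 log units; beyond the scatter) and an at least 21-fold lower number from compound 2 to compound 3 (1.32 log units; beyond the scatter) are both large.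

Compound 4 `O=C(N1CCC(F)CC1)N1CCc2nc(C#Cc3ccccc3)sc2C1` differs from compound 3 in one place: 4-fluoropiperidin-1-yl in place of (oxan-4-yl)methyl on a carbonyl carbon. Going by the values given here, both measured steps point the same way: the larger group on the carbonyl carbon, in compound 3, is the only one that brought the value within range. Compound 4 keeps a group of the same size, so a modest step, near the edge of the scatter, is expected, a 2.1-fold higher number from compound 3 to compound 4 (0.33 log units; beyond the scatter). Compound 4 is therefore estimated at 1000 nM, somewhere between 250 nM and 5000 nM.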

Compound 4, half-maximal effective concentration: 74 nM
Estimate against measurement, compound 4: 14-fold (1.13 log units) above; the measured number lies below the stated range.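

In this assay, replacing (oxan-4-yl)methyl with 4-fluoropiperidin-1-yl keeps the count of heavy atoms the same yet still gives a 6.4-fold lower number from compound 3 to compound 4 (0.80 log units; beyond the scatter), so on this carbonyl carbon the count of heavy atoms alone does not set the value. Set against the small groups, the new group gives an at least 130-fold lower number from compound 2 to compound 4 (2.13 log units; beyond the scatter) and an at least 130-fold lower number from compound 1 to compound 4 (2.13 log units; beyond the scatter). Both of these steps start from a limit of the assay rather than a number, so their full size stays unknown: the limit of > 10000 nM in this assay, at which 2 of the 4 values shown sit.

On these data alone, what the fluorine contributes remains open, and a plain piperidin-1-yl on the same carbonyl carbon would address that. A morpholin-4-yl there would show whether a ring oxygen is tolerated when a ring nitrogen is the atom bound to the carbonyl carbon.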